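This account rests on a few compounds, and the source may have more. Where it says the series, first, only, none or still open, it means among the compounds named here.

Compound 1 `COc1ccc(-c2cnc(NC(=O)C3CCNCC3)n2C)cc1`: > 100000 nM
Compound 2 `COc1ccc(-c2cnc(NC(=O)c3ccccc3OC)n2C)cc1`: > 100000 nM

In a toxicity assay on THP-1 cells (Homo sapiens) for inhibition (a higher number here means that more compound is tolerated, a lower number that less compound is tolerated), compound 2 gives > 100000 nM, which is a limit of the assay and not a number. Compound 1 also stands at a limit, so neither compound has a measured value. Compound 3 `COc1ccc(-c2cnc(NC(=O)c3ccc(Cl)cc3)n2C)cc1` changes one group of compound 2: 4-chlorophenyl in place of 2-methoxyphenyl on a carbonyl carbon. In words, 4-chlorophenyl comes in place of 2-methoxyphenyl on a carbonyl carbon. Going by the values given here, the one measured step that bears on this is a step that the two limits leave unreadable from compound 1 to compound 2, which also swaps the group on a carbonyl carbon but offers no size to carry over. Among the compounds with values here, the only guide is the limit of > 100000 nM in this assay, at which 2 of the 2 values shown sit. No step beyond the usual scatter is therefore expected in this assay, and a further limit is the likeliest report. The expected change is a number no higher from compound 2 to compound 3 (the limit leaves the size open). The estimated value for compound 3 is 100000 nM, with an expected range from 40000 nM to 100000 nM.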

Compound 3, half-maximal cytotoxic concentration: > 100000 nM
Compound 3: only a limit was reported; the forecaster's own chance of this, stated with the estimate: 80%; the middle value lies on the limit itself.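

Compound 1, compound 2 and compound 3 all give a limit of the assay and not a number, so no step among them can be read: the limit of > 100000 nM in this assay, at which 3 of the 3 values shown sit.

The compounds shown leave open the half-maximal cytotoxic concentration of each compound in this assay, and whether the group on the carbonyl carbon changes it at all.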